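The compounds below may be only part of what the source reports. "The series", "measured", "known", "first", "only" and "open" are said of these compounds alone.

Series notes. Compound 1 `Cn1c(CN2CCN(c3ccccn3)CC2)nc2ccccc21` and compound 2 `Cn1c(CN2CCN(c3ccc(C(F)(F)F)cc3)CC2)nc2ccccc21` share a core and differ in the aryl group on the piperazine. In an assay on CHO cells with metabotropic glutamate receptor 2 (Homo sapiens) as the target, read by FLIPR (a lower number here means that less compound is needed, a higher number that more compound is needed for the effect), compound 1 gives 15800 nM, whereas compound 2 gives 200 nM, the lowest of the two numbers, a gap well beyond the scatter. Compound 3 `Cn1c(CN2CCN(c3ccc(C#N)cc3)CC2)nc2ccccc21` is not yet measured; its change from compound 2 is cyano in place of trifluoromethyl on an aromatic carbon. Among the compounds with values here, no comparable step is available in this set, so the expected step is moderate: a modest rise in this assay, expected as a 2.5-fold higher number from compound 2 to compound 3 (0.40 log units; beyond the scatter). For compound 3 the estimate is 500 nM, with a range from 150 nM to 2000 nM.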

Compound 3, half-maximal effective concentration: > 12500 nM
Compound 3: only a limit was reported; the forecaster's own chance of this, stated with the estimate: 5%; middle value at least 25-fold (1.39 log units) from the limit.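

On the aromatic carbon para to a large group, replacing trifluoromethyl with cyano is far from neutral in this assay, giving an at least 62-fold higher number from compound 2 to compound 3 (1.79 log units; beyond the scatter). Compound 3 carries a limit, > 12500 nM, and not a number. Compound 1 and compound 2 differ in the whole aryl group, whereas this step isolates a single group on the ring and shows that the result depends strongly on what sits there.

The step from compound 1 to compound 3 cannot be read. Still open, going by these compounds, is how a chloro or methoxy group at this place would read out.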